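The compounds below may be only part of what the source reports. "The series", "measured", "known", "first", "only" and "open" are said of these compounds alone.

In an ADME assay on MDCK cells (Canis lupus familiaris) for cytotoxicity, read by crystal violet staining, with a stated time of 48 h (on this read-out lower numbers stand for higher toxicity in this test and higher numbers for lower toxicity in this test), compound 1 `COc1c(CCCCC(C)C)coc(=O)c1C` gives 1880000 nM as its reading, and compound 2 `CCC(C)CCCCc1coc(=O)c(C)c1OC` gives 1550000 nM on the same scale. Among the compounds with values here, these are the only two numbers so far, and they lie within the scatter of each other. Compound 3 `Cc1c(O)c(CCCCC(C)C)coc1=O` differs from compound 1 at one place: hydrogen in place of methyl on an oxygen on an aromatic ring in other words, methoxy to hydroxy. Within the data shown here, the single measured step is a 1.2-fold lower number from compound 1 to compound 2 (0.08 log units; within the scatter) and it concerns a methyl on a saturated chain carbon, not the oxygen on the ring. Among the measured compounds shown here, it therefore offers only weak guidance, and no measured step covers this change. No direction can be argued, so no shift beyond the scatter is expected in this assay for now. The expected step is a 1.3-fold lower number from compound 1 to compound 3 (0.10 log units; within the scatter) with wide uncertainty. Compound 3 is estimated at 1500000 nM as a reading. Its expected range runs from 500000 nM to 3500000 nM for now.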

Compound 3, half-maximal cytotoxic concentration: 1290000 nM
Compound 3: the middle estimate sits 1.2-fold (0.07 log units) above what was measured; the measured number falls inside the stated range.
By their numbers in this assay, from the lowest: compounds 3, 2 and 1 (each within the scatter of the next).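

Methoxy to hydroxy, on an oxygen on an aromatic ring, is the first change at this position to be read, and it gives a 1.5-fold lower number from compound 1 to compound 3 (0.16 log units; within the scatter) in this assay. So compound 1 and compound 3 cannot be told apart in this test, and in this one pair the methyl on that oxygen shows no effect on the reading that stands clear of the usual scatter. No measurement here bears on why the two readings lie so close.

Still open, from the compounds shown here alone, is how this position would read with a larger group on the oxygen, such as ethoxy, or with an amine in place of the oxygen. Going by these compounds, it is also open whether the same swap would read alike on the side chain of compound 2, since one pair cannot establish a general pattern.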